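A few compounds are considered here, and "the series" means these few. Any claim that something is new, unique, unknown or untested is made for them only; others in the source may bear on it.

Compound 1 `C/C(=C\c1cc(-c2ccccc2)cs1)C(N)=O` gives 12700 nM in a functional assay on HeLa cells (Homo sapiens) for cytotoxicity, read by CCK-8 assay, with a stated time of 24 h (on this read-out higher numbers stand for weaker inhibition and lower numbers for stronger inhibition), the lowest of the two numbers measured, though compound 2 `C/C(=C\c1cc(-c2ccccc2C)cs1)C(N)=O`, which gives 19400 nM, sits within the scatter of it. Among the compounds with values here, the only measured step, a 1.5-fold higher number from compound 1 to compound 2 (0.18 log units; within the scatter), is the closest guide to the change now considered. Compound 3 `COc1ccc(-c2csc(/C=C(\C)C(N)=O)c2)cc1` differs from compound 1 by methoxy in place of hydrogen on an aromatic carbon. Since the one comparable substitution on that ring gave a 1.5-fold higher number from compound 1 to compound 2 (0.18 log units; within the scatter), a change within the scatter, compound 3 is expected to show no step beyond the scatter, a 1.0-fold higher number from compound 1 to compound 3 (0.01 log units; within the scatter). Compound 3 is therefore estimated at 13000 nM, within a range of 5500 nM to 32000 nM.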

Compound 3, half-maximal inhibitory concentration: > 50000 nM
Compound 3 gave a limit, no number; the forecaster's own chance of this, stated with the estimate: 5%; middle value at least 3.8-fold (0.58 log units) away from the limit.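

In this assay, a substituent on the six-membered aromatic ring of carbon only can matter: methoxy, para to a large group, gives an at least 3.9-fold higher number from compound 1 to compound 3 (0.59 log units; beyond the scatter), a step beyond the scatter, whereas the methyl step, a 1.5-fold higher number from compound 1 to compound 2 (0.18 log units; within the scatter), stays within it. For compound 3 the read-out is a limit and not a number: the limit of > 50000 nM in this assay, at which 1 of the 3 values shown sits.

The compounds shown leave open how far the read-out moves with methoxy, and whether this step goes with the oxygen or with the number of heavy atoms that enter. A hydroxy group or an ethyl group at the same place would begin to separate the two.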